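This account rests on a few compounds, and the source may have more. Where it says the series, first, only, none or still open, it means among the compounds named here.

Working notes on the series. Compound 1 `CO/N=C(\C)COc1ccc2c(=O)c(-c3ccccc3)coc2c1` is the reference point for the step considered here. In a functional assay on SK-HEP1 cells (Homo sapiens) for antiproliferative activity (a higher number here means a weaker inhibitor of growth, a lower number a stronger inhibitor of growth), compound 1 gives 6400000 nM, the highest of the three numbers in hand. Compound 3 `CO/N=C(/COc1ccc2c(=O)cc(-c3ccccc3)oc2c1)c1ccc(F)cc1` in this assay gives 3300000 nM, a number that sits within the usual scatter of that of compound 1. Compound 2 `O=c1cc(-c2ccccc2)oc2ccc(OC/C(=N/O)c3ccc(F)cc3)cc12` in this assay gives 2800000 nM, a lower number than compound 1 by a margin that lies beyond the scatter. Compound 4 `CO/N=C(/COc1ccc2c(=O)c(-c3ccccc3)coc2c1)c1ccccc1`, not yet measured, differs from compound 1 by phenyl in place of methyl on a carbon with a double bond to nitrogen. Going by the values given here, no step between measured compounds isolates this change, so its size must be guessed; compound 3, which carries an aryl group at the corresponding carbon within a differently arranged core, shows only a number within the scatter of compound 1. The step from compound 1 to compound 4 is expected to be small, a 1.8-fold lower number from compound 1 to compound 4 (0.26 log units; within the scatter), towards a somewhat lower number. Compound 4 is therefore estimated at 3500000 nM, in the range from 1200000 nM to 10000000 nM.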

Compound 4, concentration for 50% growth inhibition: 7400000 nM
For compound 4 the middle estimate is 2.1-fold (0.33 log units) below the measured one; measured number inside the range.
By their numbers in this assay, from the lowest: compounds 2, 3, 1 and 4 (each within the scatter of the next, the first and the last beyond it).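

The change from methyl to phenyl on a carbon with a double bond to nitrogen now has a direct reading in this assay, with the rest of compound 1 held constant: a 1.2-fold higher number from compound 1 to compound 4 (0.06 log units; within the scatter). Going by these compounds alone, this position therefore accepts a much larger aromatic group with no change beyond the scatter, which the earlier compounds, with their differently arranged cores, could not show. No supporting measurement bears on this result.

As far as these compounds go, whether an amine, a carboxylic acid or a longer chain at this carbon would move the number remains open. Also open, from the compounds shown here alone, is whether a substituted phenyl would behave like phenyl on this core.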